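Cyclohexyl for oxolan-3-yl on a shared amine nitrogen

A few compounds are considered here, and "the series" means these few. Any claim that something is new, unique, unknown or untested is made for them only; others in the source may bear on it.

Compounds measured so far:
- compound 1, `CN(c1nc2ccc(NC(=O)CCc3ccc(C(F)(F)F)cc3)cc2[nH]1)C1CC1`: "not determined" (no result reported)
- compound 2, `CN(c1nc2ccc(NC(=O)CCc3ccc(C(F)(F)F)cc3)cc2[nH]1)C1CCOC1`: "not determined" (no result reported)
- compound 3, `CC(C)N(C)c1nc2ccc(NC(=O)CCc3ccc(C(F)(F)F)cc3)cc2[nH]1`: 21 nM

Three compounds share one core and differ only in the group carried on a nitrogen on an aromatic ring. In a functional assay on CHO-K1 cells for antagonist activity at melanin-concentrating hormone receptor 1 (Homo sapiens), read by FLIPR and calcium flux (on this read-out lower numbers stand for stronger inhibition and higher numbers for weaker inhibition), compound 3 gives 21 nM. For compound 1 no result is reported in this assay. For compound 2 there is likewise no single number in this assay, so compound 2 cannot be placed against compound 3 at all; the only measured point in this series is compound 3.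

The step considered here leads from compound 2 to compound 4, `CN(c1nc2ccc(NC(=O)CCc3ccc(C(F)(F)F)cc3)cc2[nH]1)C1CCCCC1`. The change is cyclohexyl in place of oxolan-3-yl on a nitrogen on an aromatic ring. Since compound 2 has no number, no size or direction of step in this assay can be stated from compound 2 itself; the expectation rests on compound 3 alone, which carries a small saturated group on the same nitrogen and gives 21 nM.

Compound 4 is therefore expected to fall near that value, at an estimated 30 nM, with a range from 8 nM to 120 nM.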

Compound 4, half-maximal inhibitory concentration: 27 nM
Estimate against measurement, compound 4: 1.1-fold (0.05 log units) above; the range from low to high includes it.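

In this assay, cyclohexyl in place of isopropyl on a nitrogen on an aromatic ring gives a 1.3-fold higher number from compound 3 to compound 4 (0.11 log units; within the scatter). This position therefore accepts a six-membered ring of carbon only as well as the open-chain isopropyl group, and the series now has two measured points that cannot be told apart, where before it had one. The step from compound 2 to compound 4 cannot be read, as compound 2 has no single number, and nothing measured here explains why compound 3 and compound 4 read alike.

The compounds shown leave open whether a ring oxygen such as that of oxolan-3-yl matters at this position, and whether a small ring such as the cyclopropyl of compound 1 would read like the cyclohexyl of compound 4. They also leave open how far this acceptance reaches, for instance whether a phenyl ring, a longer chain such as hexyl, or a cyclohexyl ring carrying an amine or a carboxylic acid would keep the number in the same range.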